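Varying the aryl amide of a shared core: compound 4

A few compounds are considered here, and "the series" means these few. Any claim that something is new, unique, unknown or untested is made for them only; others in the source may bear on it.

The three measured compounds share one core and differ only in the aryl group on the amide nitrogen. Compound 1 `Cc1ccc(NC(=O)[C@H]2CN(C)C[C@@H]2c2ccc(/C=C/C(=O)Nc3ccccc3N)cc2)cc1` gives 62 mL/min/kg in an in vitro ADME assay on microsomes from liver (Mus musculus) for pharmacokinetics, read by LC-MS, with a stated time of 10 min, tested at 1 uM; on this read-out higher numbers stand for fast clearance and lower numbers for slow clearance. Compound 2 `CC(C)c1ccc(NC(=O)[C@H]2CN(C)C[C@@H]2c2ccc(/C=C/C(=O)Nc3ccccc3N)cc2)cc1` gives 54 mL/min/kg in this assay, and compound 3 `Cc1cccc(NC(=O)[C@H]2CN(C)C[C@@H]2c2ccc(/C=C/C(=O)Nc3ccccc3N)cc2)c1` gives 74 mL/min/kg. Compound 2 has the lowest of the three numbers, but the gaps to its neighbours are small: a 1.1-fold lower number from compound 1 to compound 2 (0.06 log units; within the scatter) and a 1.4-fold higher number from compound 2 to compound 3 (0.14 log units; within the scatter) both lie within the scatter, as does a 1.2-fold higher number from compound 1 to compound 3 (0.08 log units; within the scatter), so no ranking among the three can be drawn from these data.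

Compound 4 `CN1C[C@H](C(=O)Nc2ccc(F)c(Cl)c2)[C@@H](c2ccc(/C=C/C(=O)Nc3ccccc3N)cc2)C1` has not yet been measured in this assay. It differs from compound 2 by 3-chloro-4-fluorophenyl in place of 4-isopropylphenyl on an amide-type nitrogen. The measured steps that bear on this change are the three exchanges of the aryl group on the amide nitrogen described above, and every one of them stayed within the scatter. Nothing in the measured set therefore points to a step beyond the scatter in either direction for this further exchange, and compound 4 is expected to sit close to compound 2.

Compound 4 is estimated at 60 mL/min/kg, with a range from 35 mL/min/kg to 100 mL/min/kg. The expected step is a 1.1-fold higher number from compound 2 to compound 4 (0.05 log units; within the scatter), which is anticipated to remain within the scatter.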

Compound 4, clearance: 34 mL/min/kg
Beside the measured number, compound 4's estimate is 1.8-fold (0.25 log units) above it; the measured number lies below the stated range.
By their numbers in this assay, from the lowest: compounds 4, 2, 1 and 3 (each within the scatter of the next, the first and the last beyond it).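

Among the compounds shown, only compound 4 gives a step beyond the scatter for an exchange of the aryl group on this amide-type nitrogen in this assay: a 2.2-fold lower number from compound 3 to compound 4 (0.34 log units; beyond the scatter). That step is modest, and the two other steps to compound 4 remain within the scatter, a 1.6-fold lower number from compound 2 to compound 4 (0.20 log units; within the scatter) and a 1.8-fold lower number from compound 1 to compound 4 (0.26 log units; within the scatter), so the separation holds only against compound 3 and compound 4 cannot be placed apart from compound 1 or compound 2. The position is therefore not wholly silent to change, as the earlier three compounds alone had suggested, but nothing given here accounts for the step.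

The compounds shown leave open whether the chlorine or the fluorine of the 3-chloro-4-fluorophenyl group, taken alone on the same nitrogen, would give a number that also stands apart from compound 3. They also leave open how an aryl group carrying an amine or a carboxylic acid, or a saturated ring such as cyclohexyl in place of the aryl group, would read at this position.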